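The source may report more compounds than this note shows. Statements on the series, on what has been measured and on what is new or still open speak of the compounds shown alone.

Compound 3 `CCOC(=O)c1cn(C(c2ccccc2)c2cc3cc(Br)ccc3nc2OC)nn1` belongs to a set of three close relatives that share one core and differ only in the group carried on the five-membered ring with three nitrogens. In an ADME assay on HeLa cells (Homo sapiens) for cytotoxicity, read by sulforhodamine B assay, with a stated time of 48 h, tested at 10 uM (on this read-out higher numbers stand for more inhibition at the one concentration tested (going by the name of the read-out) and lower numbers for less inhibition), compound 3 gives -3.67%, the lowest of the three numbers, yet both neighbours sit within the usual scatter of it: compound 1 `CCCCc1cn(C(c2ccccc2)c2cc3cc(Br)ccc3nc2OC)nn1` gives -2.87% and compound 2 `CCCCCCCCc1cn(C(c2ccccc2)c2cc3cc(Br)ccc3nc2OC)nn1` gives 0.1%. None of the three measured steps stands out. The change a number 3 percentage points higher from compound 1 to compound 2 (within the scatter), the change a number 0.8 percentage points lower from compound 1 to compound 3 (within the scatter) and the change a number 3.8 percentage points lower from compound 2 to compound 3 (within the scatter) are all small.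

Compound 4 `COc1nc2ccc(Br)cc2cc1C(c1ccccc1)n1cc(CCCO)nn1` is the next step from compound 3: 3-hydroxypropyl in place of ethoxycarbonyl on an aromatic carbon. For the measured compounds named here, no measured step introduces a 3-hydroxypropyl, so the guide is only that swapping ethoxycarbonyl for a butyl or an octyl, and lengthening that chain, all left this assay essentially unchanged. The step of a number 2.7 percentage points higher from compound 3 to compound 4 (within the scatter) is therefore expected to stay within the scatter. For compound 4 the expected value is -1%, with a range from -8% to 6%.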

Compound 4, a percentage reported as inhibition, at one concentration (the size of the read-out at that concentration, not a potency): 11.3%
Estimate against measurement, compound 4: 12.3 percentage points below; the measured number lies above the stated range.
By their numbers in this assay, from the lowest: compounds 3, 1 and 2 (each within the scatter of the next); then compound 4.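

In this assay, for the compounds shown here, the group on this aromatic carbon of the five-membered ring with 3 nitrogen can shift the number after all: a number 15 percentage points higher from compound 3 to compound 4 (beyond the scatter), the first step in this set to lie beyond the scatter. The two plain chains give the same picture, with a number 11.2 percentage points higher from compound 2 to compound 4 (beyond the scatter) and a number 14.2 percentage points higher from compound 1 to compound 4 (beyond the scatter), so among these four compounds only compound 4, the one whose chain ends in a hydroxy group, stands apart from the others. No measurement at hand gives a reason for this rise.

On these data alone, whether the hydroxy group itself or the length of the chain that carries it matters remains open. A 2-hydroxyethyl or a 4-hydroxybutyl chain would address the length, while a 3-methoxypropyl or a 3-aminopropyl chain would address the hydroxy group.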